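The compounds below may be only part of what the source reports. "The series", "measured", "known", "first", "only" and "open" are said of these compounds alone.

In a functional assay on KG-1a cells (Homo sapiens) for inhibition, read by MTT assay, with a stated time of 72 h (on this read-out higher numbers stand for weaker inhibition and lower numbers for stronger inhibition), compound 1, whose structure is `Cc1ccc(-n2cc(-c3ccc(CN4CCN(C)CC4)c(C(F)(F)F)c3)nn2)cc1Nc1nccc(-c2cccnc2)n1`, gives 1270 nM. Compound 2, with the structure `Cc1ccc(-n2cc(-c3ccc(C)c(C(F)(F)F)c3)nn2)cc1Nc1nccc(-c2cccnc2)n1`, differs from it by one change: hydrogen in place of 4-methylpiperazin-1-yl on a saturated chain carbon bound to an aromatic carbon. For compound 2 this assay reports only a limit, > 30000 nM, and that limit is the limit of > 30000 nM in this assay, at which 1 of the 3 values shown sits. The measured step is therefore an at least 23-fold higher number from compound 1 to compound 2 (1.37 log units; beyond the scatter), a large loss of potency on removing the 4-methylpiperazin-1-yl group from the saturated chain carbon bound to an aromatic carbon.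

Compound 3, whose structure is `Cc1ccc(-c2nnc(-c3ccc(CN4CCN(C)CC4)c(C(F)(F)F)c3)o2)cc1Nc1nccc(-c2cccnc2)n1`, carries a different core; how the core of compound 3 differs from that of compound 1 is not broken down here. In this assay compound 3 gives 580 nM, the lowest number among the two compounds with a number, and it stands apart from compound 1 by a gap beyond the usual scatter.

Compound 4, whose structure is `Cc1ccc(-c2nnc(-c3ccc(C)c(C(F)(F)F)c3)o2)cc1Nc1nccc(-c2cccnc2)n1`, is the counterpart of compound 3 in which the same change is made: hydrogen in place of 4-methylpiperazin-1-yl on a saturated chain carbon bound to an aromatic carbon. The place of the change is described in identical words for both pairs, so it is the same change on a different core. Compound 4 is expected to give 15000 nM, with a range from 4000 nM to 30000 nM. The expected step of a 26-fold higher number from compound 3 to compound 4 (1.41 log units; beyond the scatter) rests on the measured step of an at least 23-fold higher number from compound 1 to compound 2 (1.37 log units; beyond the scatter), which was large, and it is expected that compound 4 may likewise reach only a limit in this assay.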

Compound 4, half-maximal inhibitory concentration: > 30000 nM
Compound 4 ended at the assay's limit (the forecaster's own chance of this, stated with the estimate: 55%); middle value at least 2.0-fold (0.30 log units) away from the limit.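

In this assay, replacing the 4-methylpiperazin-1-yl group with hydrogen on the saturated chain carbon bound to an aromatic carbon again gives a large step on the second core, an at least 51-fold higher number from compound 3 to compound 4 (1.71 log units; beyond the scatter). The change therefore carries over from the core of compound 1 to the core of compound 3 in its direction and in being large on both, and the two steps can be set side by side: the same change on two cores in this assay, an at least 23-fold higher number (1.37 log units; beyond the scatter) from compound 1 to compound 2 and an at least 51-fold higher number (1.71 log units; beyond the scatter) from compound 3 to compound 4; the limit leaves it open whether they differ What this does not show is how large either step really is or whether the core alters the effect of the change, as compound 2 and compound 4 each give only a limit and not a number: the limit of > 30000 nM in this assay, at which 2 of the 4 values shown sit.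

The compounds shown leave open which feature of the 4-methylpiperazin-1-yl group matters, and whether another group on the same saturated chain carbon, such as a dimethylamino group, a morpholine ring or a carboxylic acid, would keep a measurable number in this assay. Going by these compounds alone, they also leave open whether the same change would behave alike on a third core, since only two cores appear here.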